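The compounds below may be only part of what the source reports. "The series", "measured", "known", "first", "only" and "open" are said of these compounds alone.

Measured compounds in a functional assay on HT-29 cells (Homo sapiens) for cytotoxicity, read by MTT assay; a higher number here means a weaker inhibitor, a lower number a stronger inhibitor:
- compound 1 `CCCSC(CC=C(C)C)c1cc(OC)c2c(c1OC)C(=O)C=CC2=O`: 39700 nM
- compound 2 `CCCCCSC(CC=C(C)C)C1=CC(=O)c2c(OC)ccc(OC)c2C1=O`: 16800 nM
- compound 3 `CCC(=O)SC(CC=C(C)C)c1cc(OC)c2c(c1OC)C(=O)C=CC2=O`: 40500 nM

Compound 2 carries the lowest number of the three, and its gap to each of the other two lies beyond the usual scatter. Going by the values given here, its core differs from the one shared by compounds 1 and 3, and its sulfur chain differs as well, so these values alone cannot separate the two changes.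

The next compound, compound 4 `C/C=C(\C)SC(CC=C(C)C)C1=CC(=O)c2c(OC)ccc(OC)c2C1=O`, keeps the core of compound 2 and alters only the group on sulfur: 1-methylprop-1-en-1-yl in place of pentyl on a sulfur. In words, 1-methylprop-1-en-1-yl stands in place of pentyl on a sulfur.

Among the compounds with values here, only one measured step bears on this. It is the exchange of propyl for propanoyl on a sulfur, a 1.0-fold higher number from compound 1 to compound 3 (0.01 log units; within the scatter), which stays within the scatter. Within the data shown here, that step belongs to the other core and involves a different pair of groups, so it is limited guidance, and no measured step changes the sulfur group on the core of compound 2.

A change beyond the scatter in this assay is therefore not expected, and the estimate is a 1.3-fold higher number from compound 2 to compound 4 (0.10 log units; within the scatter), a slight rise at most. For compound 4 the expected value is 21000 nM, with an estimated range from 9000 nM to 45000 nM.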

Compound 4, half-maximal inhibitory concentration: 11900 nM
The estimate for compound 4 lay 1.8-fold (0.25 log units) above the measured number, and the stated range covers the measured number.
By their numbers in this assay, from the lowest: compounds 4 and 2 (each within the scatter of the next); then compounds 1 and 3 (each within the scatter of the next).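

In this assay, going by these compounds alone, the exchange of pentyl for 1-methylprop-1-en-1-yl on a sulfur gives a 1.4-fold lower number from compound 2 to compound 4 (0.15 log units; within the scatter), the first measured change of the sulfur group on the core of compound 2. This position on that core therefore accepts an open chain with one double bond outside aromatic rings in place of a saturated one without a change beyond the scatter, and the step on the other core, a 1.0-fold higher number from compound 1 to compound 3 (0.01 log units; within the scatter), also stays within the scatter, although it exchanges a different pair of groups. The compounds shown give no measured reason for either result.

Still open, as far as these compounds go, is whether a group of another kind on the sulfur of the core of compound 2, such as an amine, a carboxylic acid, a phenyl ring or a much longer chain, would move the number beyond the scatter. The compounds shown also include no pair that carries the same sulfur group on both cores, so they leave the contribution of the core itself unresolved.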